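The source may hold more compounds than are shown below. What is called first, only, known or untested is meant among the compounds shown, and "the series" means these compounds.

Measured in a functional assay on MKN-45 cells (Homo sapiens) for inhibition, with a stated time of 72 h; a higher number here means a weaker inhibitor, a lower number a stronger inhibitor:
- compound 1 `COc1ccc(S(=O)(=O)N2CCc3cccc(-c4ccc(F)nc4)c32)cc1`: 145 nM
- compound 2 `COc1ccc(S(=O)(=O)N2CCc3cccc(-c4cccc(F)c4)c32)cc1`: 84.7 nM
- compound 3 `COc1ccc(S(=O)(=O)n2ccc3cccc(-c4ccc(C#N)cc4)c32)cc1`: 143 nM

Compound 3, at 143 nM, lies within the usual scatter of both compound 1 and compound 2, so these three values cannot be ranked. Compound 4 `COc1ccc(S(=O)(=O)n2ccc3cccc(-c4ccc(F)cc4)c32)cc1` has not been measured. It carries fluoro in place of cyano on an aromatic carbon, para to a large group (fluoro in place of cyano on an aromatic carbon). Among the compounds with values here, no measured pair makes this exact swap. Within the data shown here, the only measured step, a 1.7-fold lower number from compound 1 to compound 2 (0.23 log units; within the scatter), exchanges a different pair of groups, and on a core that is not the one compound 3 carries. It is therefore only a weak guide. Starting from compound 3 at 143 nM, no shift beyond the scatter is expected in this assay, and the direction is open. The estimate corresponds to a 1.2-fold lower number from compound 3 to compound 4 (0.08 log units; within the scatter), an expected step within the scatter. Compound 4 is estimated at 120 nM, with an expected range from 45 nM to 320 nM.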

Compound 4, half-maximal inhibitory concentration: 170 nM
For compound 4 the middle estimate is 1.4-fold (0.15 log units) below the measured one, within the range that was stated.
By their numbers in this assay, from the lowest: compounds 2, 3, 1 and 4 (each within the scatter of the next).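

In this assay, putting fluoro in place of cyano on this aromatic carbon, para to a large group, gives a 1.2-fold higher number from compound 3 to compound 4 (0.08 log units; within the scatter). Within the data shown here, this is the first direct reading at this position: the earlier step exchanged different groups on a different core, whereas here the 4-cyanophenyl to 4-fluorophenyl exchange, which swaps a group counted as one hydrogen-bond acceptor for one counted as none, gives two numbers that cannot be told apart. Nothing available explains this result.

Going by these compounds, whether an amine or a carboxylic acid on this same carbon would give a number clearly apart from these remains open. Also open, on these data alone, is whether the 4-cyanophenyl to 4-fluorophenyl exchange would read the same way on the core of compound 1.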